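The compounds below may be only part of what the source reports. "The series", "measured", "known", "first", "only" and "open" are said of these compounds alone.

Measured so far in a functional assay on HCT-116 cells (Homo sapiens) for antiproliferative activity, read by MTT assay, with a stated time of 72 h (on this read-out lower numbers stand for stronger inhibition and higher numbers for weaker inhibition), for three compounds:
- compound 1 `COc1ccc(OCCCON2C(N)=NC(N)=NC23CCOCC3)cc1` gives 1500 nM
- compound 2 `NC1=NC2(CCSCC2)N(OCCCOc2cccc(Cl)c2)C(N)=N1` gives 1 nM
- compound 3 `NC1=NC2(CCSCC2)N(OCCCOc2ccc(Br)cc2)C(N)=N1` gives 20 nM

Compound 1 at 1500 nM is the highest number of the three, and both other values lie beyond the scatter from it. Still unmeasured is compound 4 `NC1=NC2(CCOCC2)N(OCCCOc2cccc(Cl)c2Cl)C(N)=N1` with the core of compound 1 kept and one change, 2,3-dichlorophenyl in place of 4-methoxyphenyl on an oxygen on a saturated carbon in words 2,3-dichlorophenyl in place of 4-methoxyphenyl on an oxygen on a saturated carbon.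

For the measured compounds named here, only one measured step bears on this, and only indirectly. The a 20-fold higher number from compound 2 to compound 3 (1.30 log units; beyond the scatter) shows that a swap at this same place can move the number a long way. Compound 2 at 1 nM holds the nearest group to the incoming one, but compounds 2 and 3 carry a core different from that of compound 1. Going by the values given here, no measured pair isolates the effect of that core difference, and 2,3-dichlorophenyl itself has no measured precedent, so the expectation is loose. In this assay the estimate is a 50-fold lower number from compound 1 to compound 4 (1.70 log units; beyond the scatter) as a large expected move toward a lower number. For compound 4 the expected value is 30 nM within an estimated range of 3 nM to 300 nM in this read-out.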

Compound 4, half-maximal inhibitory concentration: 5 nM
For compound 4 the middle estimate is 6.0-fold (0.78 log units) above the measured one, within the range that was stated.
By their numbers in this assay, from the lowest: compound 2; then compound 4; then compound 3; then compound 1.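

In this assay, for the compounds shown here, the step of a 300-fold lower number from compound 1 to compound 4 (2.48 log units; beyond the scatter) is the first one read with the core of compound 1 held fixed, and it shows that the group on this oxygen on a saturated carbon can carry a large change on that core, as a 20-fold higher number from compound 2 to compound 3 (1.30 log units; beyond the scatter) showed on the other core. The high number of compound 1 therefore cannot be read as a fixed feature of its core, since compound 4 carries the same core and gives 5 nM in this assay. Nothing at hand accounts for the size of this step.

Still open, going by these compounds, is how much of the step belongs to the loss of the 4-methoxyphenyl group and how much to the entry of the 2,3-dichlorophenyl group, a split that a plain phenyl or a single chlorine on the same core would help to resolve. Going by these compounds alone, also open is what the core difference contributes, since no pair carries one aryl group on both cores, and whether a longer chain or an amine at this place keeps the low numbers.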